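Swapping bromo for ethyl on an aryl ether antiproliferative

This account rests on a few compounds, and the source may have more. Where it says the series, first, only, none or still open, it means among the compounds named here.

The study measured antiproliferative activity in a functional assay on A549 cells (Homo sapiens) for antiproliferative activity, read by CCK-8 assay, with a stated time of 72 h; a higher number here means a weaker inhibitor, a lower number a stronger inhibitor. Compound 1, `Nc1ccccc1NC(=O)c1ccc(COc2ccc(Br)cc2)cc1`, gives 24400 nM there, the higher of the two numbers available. Compound 2, `Nc1ccccc1NC(=O)/C=C/c1ccc(CN2CCc3ccccc32)cc1`, gives 13400 nM; the two values lie within the scatter of each other, so neither can be called the stronger inhibitor. Compound 3, `Nc1ccccc1NC(=O)c1ccc(CN2CCc3cc(Br)ccc32)cc1`, is recorded as "not determined" (no result reported) in this assay, so no number is available for it.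

Compound 4, `CCc1ccc(OCc2ccc(C(=O)Nc3ccccc3N)cc2)cc1`, differs from compound 1 in one place: ethyl in place of bromo on an aromatic carbon. Ethyl is close in size to bromo, and nothing among the measured compounds shows how this assay responds to such an exchange. Among the compounds with values here, with no measured step to lean on, the expected change from compound 1 to compound 4 is none beyond the scatter, and the expected step of a 1.0-fold higher number from compound 1 to compound 4 (0.01 log units; within the scatter) reflects that. For compound 4 the estimate in this assay is 25000 nM, with a range from 10000 nM to 60000 nM expected to cover most repeat measurements.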

Compound 4, half-maximal inhibitory concentration: 6420 nM
Estimate against measurement, compound 4: 3.9-fold (0.59 log units) above; measured number outside the range, below it.
By their numbers in this assay, from the lowest: compound 4; then compounds 2 and 1 (each within the scatter of the next).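

In this assay, within the data shown here, ethyl in place of bromo on this aromatic carbon, para to a large group, gives a 3.8-fold lower number from compound 1 to compound 4 (0.58 log units; beyond the scatter) and so supplies the only measured step. It shows that this position is not indifferent to its substituent: the 4-bromophenyl to 4-ethylphenyl exchange, in which 2 carbon atoms replace 1 bromine, moves the number by more than repeat measurements would. No measurement shown bears on why the number falls.

As far as these compounds go, whether the shift belongs to ethyl itself or to the loss of bromo stays open, as does how a longer chain such as propyl, a methoxy group or an amine would behave at the same place. A single pair also cannot say whether the exchange would act alike on another core, such as that of compound 3, which carries bromo but has no number.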